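Swapping a Five-Membered Heteroaryl Ring on the Piperidine Nitrogen

This account rests on a few compounds, and the source may have more. Where it says the series, first, only, none or still open, it means among the compounds named here.

Four compounds share a common core that carries, on an amine nitrogen in a ring, a small aromatic group. Compound 1 `COC(=O)c1cnc(N2CCC(CCCNc3ccc4c(c3)OCC4=O)CC2)nc1` bears a methoxycarbonyl-substituted pyrimidine there; in a functional assay on CHO-K1 cells for agonist activity at Glucose-dependent insulinotropic receptor (Mus musculus), read by HTRF and cAMP accumulation, with a stated time of 30 min (a lower number here means that less compound is needed, a higher number that more compound is needed for the effect), compound 1 gives 139 nM. Compound 2 `CC(C)c1noc(N2CCC(CCCNc3ccc4c(c3)OCC4=O)CC2)n1` carries an isopropyl-substituted oxadiazole of one type, but for compound 2 the result in this assay is "not determined" (no result reported). Compound 3 `CC(C)c1nnc(N2CCC(CCCNc3ccc4c(c3)OCC4=O)CC2)o1` carries the isomeric 5-isopropyl-1,3,4-oxadiazol-2-yl, and in this assay compound 3 gives 1020 nM. Among the two numbers available, compound 3 stands highest, since the step of a 7.3-fold higher number from compound 1 to compound 3 (0.87 log units; beyond the scatter) lies beyond the scatter.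

Compound 4 `CC(C)c1nsc(N2CCC(CCCNc3ccc4c(c3)OCC4=O)CC2)n1` differs from compound 3 in one place: 3-isopropyl-1,2,4-thiadiazol-5-yl in place of 5-isopropyl-1,3,4-oxadiazol-2-yl on an amine nitrogen in a ring. For the measured compounds named here, none of the measured steps touches this change directly; the only step on record, from compound 1 to compound 3, exchanges a six-membered for a five-membered ring and does not tell how an oxygen-to-sulfur swap within a five-membered ring behaves. With the same count of hydrogen-bond acceptors and the same ring size, the expectation is a step of about a 1.5-fold lower number from compound 3 to compound 4 (0.16 log units; within the scatter), which is within the scatter. Compound 4 is therefore estimated at 700 nM in this assay, with a range from 200 nM to 2500 nM.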

Compound 4, half-maximal effective concentration: 812 nM
For compound 4 the middle estimate is 1.2-fold (0.06 log units) below the measured one; the measured number falls inside the stated range.
By their numbers in this assay, from the lowest: compound 1; then compounds 4 and 3 (each within the scatter of the next).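

In this assay, replacing one isopropyl-bearing five-membered aromatic ring with another gives a 1.3-fold lower number from compound 3 to compound 4 (0.10 log units; within the scatter) and stays within the scatter, so at this place on the amine nitrogen in a ring, the 5-isopropyl-1,3,4-oxadiazol-2-yl and 3-isopropyl-1,2,4-thiadiazol-5-yl groups cannot be told apart, even though one ring holds oxygen and the other sulfur. The second comparison gives a 5.8-fold higher number from compound 1 to compound 4 (0.77 log units; beyond the scatter) and lies beyond the scatter, so the gap first seen with the 1,3,4-oxadiazole also appears with a second five-membered ring, a pattern that rests on these two rings alone. Nothing available explains this shared behaviour or the gap to the 5-(methoxycarbonyl)pyrimidin-2-yl group.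

As far as these compounds go, the step away from compound 1 changes the ring and its substituent together, so it remains open whether the pyrimidine ring, the methoxycarbonyl group or the pair of them goes with the lower number. A pyrimidine carrying isopropyl, or a thiadiazole carrying methoxycarbonyl, would separate these two parts, and a carboxylic acid in place of the methyl ester would probe the substituent further.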